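Fluoro for hydroxy on the hydrazone aryl ring

The compounds below may be only part of what the source reports. "The series", "measured", "known", "first", "only" and "open" are said of these compounds alone.

Measured compounds:
compound 1 `CN(C)CCn1cnnc1-c1cc(Oc2ccc(NC(=O)N/N=C/c3ccc(Cl)cc3Cl)cc2F)ccn1` gives 390 nM in a functional assay on HT-29 cells (Homo sapiens) for cytotoxicity, read by MTT assay, with a stated time of 72 h; a lower number here means a stronger inhibitor, a higher number a weaker inhibitor
compound 2 `COc1ccc(OC)c(/C=N/NC(=O)Nc2ccc(Oc3ccnc(-c4nncn4CCN(C)C)c3)c(F)c2)c1` gives 2070 nM in this assay
compound 3 `CN(C)CCn1cnnc1-c1cc(Oc2ccc(NC(=O)N/N=C/c3ccc(O)c(O)c3)cc2F)ccn1` gives 1890 nM in this assay

Compound 3 stands second highest of the three numbers; it lies within the scatter of compound 2 (a 1.1-fold lower number from compound 2 to compound 3 (0.04 log units; within the scatter)) and well above compound 1 (a 4.8-fold higher number from compound 1 to compound 3 (0.69 log units; beyond the scatter)). All measured steps sit on the aryl ring attached to the carbon with a double bond to nitrogen: a 5.3-fold higher number from compound 1 to compound 2 (0.72 log units; beyond the scatter) and a 4.8-fold higher number from compound 1 to compound 3 (0.69 log units; beyond the scatter) were both modest, while a 1.1-fold lower number from compound 2 to compound 3 (0.04 log units; within the scatter) was within the scatter.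

Compound 4 `CN(C)CCn1cnnc1-c1cc(Oc2ccc(NC(=O)N/N=C/c3ccc(O)c(F)c3)cc2F)ccn1` differs from compound 3 by fluoro in place of hydroxy on an aromatic carbon. Among the compounds with values here, no measured step exchanges hydroxy for fluoro at this place, so the bearing steps are only the modest ones from compound 1; they show that changes on this ring move the number by a modest amount at most. A small step in this assay toward the number of compound 1 is expected, a 1.6-fold lower number from compound 3 to compound 4 (0.20 log units; within the scatter), though a result within the scatter is also plausible. Compound 4 is therefore estimated at 1200 nM, with a range from 450 nM to 3200 nM.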

Compound 4, half-maximal inhibitory concentration: 3310 nM
For compound 4 the middle estimate is 2.8-fold (0.44 log units) below the measured one; the measured number lies above the stated range.
By their numbers in this assay, from the lowest: compound 1; then compounds 3, 2 and 4 (each within the scatter of the next).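

In this assay, within the data shown here, the first direct reading of fluoro in place of hydroxy at this place (the change from 3,4-dihydroxyphenyl to 3-fluoro-4-hydroxyphenyl) is within the scatter (a 1.8-fold higher number from compound 3 to compound 4 (0.24 log units; within the scatter)), so this exchange does not separate the two compounds. Compound 4 also lies within the scatter of the 2,5-dimethoxyphenyl compound (a 1.6-fold higher number from compound 2 to compound 4 (0.20 log units; within the scatter)), while the 2,4-dichlorophenyl compound remains apart from it (an 8.5-fold higher number from compound 1 to compound 4 (0.93 log units; beyond the scatter)), so among these four compounds only compound 1 stands clearly apart. No measurement shown here explains these differences.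

From the compounds shown here alone, it remains open whether an amine or a carboxylic acid in place of the fluoro would give a number outside this cluster. Going by these compounds, it is also open whether a single chloro on this ring would be enough to approach compound 1.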